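Fluoro for Methyl: Estimating Compound 3

This account rests on a few compounds, and the source may have more. Where it says the series, first, only, none or still open, it means among the compounds named here.

Measured so far in a functional assay on U-87MG ATCC cells (Homo sapiens) for cytotoxicity, read by MTT assay, with a stated time of 72 h; a higher number here means a weaker inhibitor, a lower number a stronger inhibitor:
compound 1 `COc1cc2c(Oc3ccc(NC(=O)c4cc(-c5ccc(F)cc5)ccn4)cc3F)ccnc2cc1OCCCN1CCCCC1` gives 12500 nM
compound 2 `COc1cc2c(Oc3ccc(NC(=O)c4cc(-c5ccc(C)cc5)ccn4)cc3F)ccnc2cc1OCCCN1CCCC1` gives 560 nM

Compound 2 stands lowest of the two numbers in this assay; its nearest neighbour, compound 1, lies a long way higher, beyond the scatter. Compound 3 `COc1cc2c(Oc3ccc(NC(=O)c4cc(-c5ccc(F)cc5)ccn4)cc3F)ccnc2cc1OCCCN1CCCC1` is made from compound 2 by fluoro in place of methyl on an aromatic carbon. Within the data shown here, compound 1 also carries that fluoro, but differs from compound 3 in a second place as well, so no step between measured compounds can be read. Compound 3 is expected to land between the two measured values, a step of a 5.4-fold higher number from compound 2 to compound 3 (0.73 log units; beyond the scatter) toward weaker inhibition. The estimate for compound 3 is 3000 nM, ranging from 700 nM to 13000 nM.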

Compound 3, half-maximal inhibitory concentration: 1780 nM
Compound 3: middle estimate off by 1.7-fold (0.23 log units), on the high side; the measured number falls inside the stated range.
By their numbers in this assay, from the lowest: compound 2; then compound 3; then compound 1.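

In this assay, fluoro in place of methyl on the aromatic carbon gives a 3.2-fold higher number from compound 2 to compound 3 (0.50 log units; beyond the scatter), so with the rest of the molecule held fixed, this position does influence the read-out. The second change, pyrrolidin-1-yl in place of piperidin-1-yl on the saturated chain, gives a 7.0-fold lower number from compound 1 to compound 3 (0.85 log units; beyond the scatter), a larger step than the first. Nothing available explains the cause of either step.

Still open, going by these compounds, is how other groups on this aromatic carbon, such as chloro, methoxy or a nitrile, would read. Also open, on these data alone, is whether the step from methyl to fluoro would hold with piperidin-1-yl on the chain.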